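The compounds below may be only part of what the source reports. "The series", "measured", "known", "first", "only" and "open" are said of these compounds alone.

Working notes on the series. Of the compounds shown here, two carry numbers so far. Compound 1 `Cc1nc(S(C)(=O)=O)ccc1Oc1ncnc(OC2CCN(C(=O)O[C@H](C)C(F)(F)F)CC2)c1F` gives 110 nM in a functional assay on isolated protein for inhibition of Glucose-dependent insulinotropic receptor (Rattus norvegicus), read by HTRF and cAMP accumulation; on this read-out lower numbers stand for an effect already at smaller amounts and higher numbers for an effect only at larger amounts of compound. Within the data shown here, compound 2 `Cc1nc(S(C)(=O)=O)ccc1Oc1ncnc(OC2CCN(C(=S)OC(C)C)CC2)c1F` gives 1050 nM in this assay, the higher of the two numbers; the single measured step, a 9.5-fold higher number from compound 1 to compound 2 (0.98 log units; beyond the scatter), rests on a group of 6 heavy atoms (4 carbon, 1 oxygen, 1 sulfur; no ring) in place of a group of 9 heavy atoms (4 carbon, 2 oxygen, 3 fluorine; no ring), on an amine nitrogen in a ring.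

Compound 3 `CCc1cnc(C(=O)N2CCC(Oc3ncnc(Oc4ccc(S(C)(=O)=O)nc4C)c3F)CC2)nc1` is not yet measured. It differs from compound 2 at that same nitrogen: a group of 10 heavy atoms (7 carbon, 2 nitrogen, 1 oxygen; one six-membered aromatic ring with 2 hetero atoms) in place of a group of 6 heavy atoms (4 carbon, 1 oxygen, 1 sulfur; no ring), on an amine nitrogen in a ring. Among the measured compounds shown here, the one measured step bears on it in that it shows exchanges at this position shifting the number beyond the scatter. The direction is expected to be downward, because compound 2 carries the group that went with 1050 nM and that group now leaves, while nothing measured tells how a ring-bearing group at this position behaves. For compound 3 the expected step is a 5.3-fold lower number from compound 2 to compound 3 (0.72 log units; beyond the scatter). Compound 3 is estimated at 200 nM, with a range of 50 nM to 800 nM.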

Compound 3, half-maximal effective concentration: 40.8 nM
For compound 3 the middle estimate is 4.9-fold (0.69 log units) above the measured one; the whole stated range lies above it.
By their numbers in this assay, from the lowest: compound 3; then compound 1; then compound 2.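

The position on the amine nitrogen in the ring now holds a group with a six-membered aromatic ring, and in this assay that group gives the lowest number of the series, with steps to both other compounds beyond the scatter. Among these compounds, the exchange that removes the sulfur-bearing group gives a 26-fold lower number from compound 2 to compound 3 (1.41 log units; beyond the scatter), a large step that shows this position can move the number downward as well as upward, and by more than the one step measured before. Against the better of the two earlier groups, 5-ethylpyrimidin-2-yl in place of 1-(trifluoromethyl)ethoxy on a carbonyl carbon gives a 2.7-fold lower number from compound 1 to compound 3 (0.43 log units; beyond the scatter), so a carbamate-type link to the ring nitrogen is not needed for a number at this level, and nothing at hand accounts for either step.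

On these data alone, how much of the gain belongs to the ethyl remains open, since a propyl chain, a methoxy group or a plain hydrogen in its place could each move the number either way. Equally open, as far as these compounds go, is what a phenyl ring, a pyridine ring with its single ring nitrogen, or a saturated piperidine ring would give on the same carbonyl carbon.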